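The source may hold more compounds than are shown below. What is called first, only, known or untested is meant among the compounds shown, and "the series" means these compounds.

Measured compounds:
- compound 1, `COC(=O)/C=C\NC(=O)[C@H](O)C(C)(C)CO`: in an ADME assay on WI-38 cells (Homo sapiens) for inhibition, read by CellTiter-Glo, with a stated time of 48 h, tested at 100 uM (on this read-out lower numbers stand for less inhibition and higher numbers for more inhibition at the one concentration tested (going by the name of the read-out)), compound 1 gives "not determined" (no result reported)
- compound 2, `CC(C)(C)OC(=O)/C=C\NC(=O)[C@H](O)C(C)(C)CO`: in this assay compound 2 gives -14%

Among the measured compounds shown here, compound 2 holds the only number; the entry for compound 1 carries no figure, so no step between measured compounds can be drawn and nothing is known about how this core answers to any change. The read-out of compound 2 sits near zero, showing no inhibition at the single concentration tested.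

Compound 3, `CCOC(=O)/C=C\NC(=O)[C@H](O)C(C)(C)CO`, is the next entry. It differs from compound 2 in one place: ethyl in place of tert-butyl on an oxygen next to a carbonyl group.

For the measured compounds named here, with no measured step to lean on, the expected step in this assay is a number 6 percentage points higher from compound 2 to compound 3 (within the scatter), that is none beyond the usual scatter. This is expected because compound 2 gives -14%, a starting value that leaves little room for a drop, and the change is a small one. The estimate for compound 3 in this assay is -8%, with a range from -28% to 12%.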

Compound 3, a percentage reported as inhibition, at one concentration (the size of the read-out at that concentration, not a potency): 1%
For compound 3 the middle estimate is 9 percentage points below the measured one, and the stated range covers the measured number.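

Ethyl in place of tert-butyl on an oxygen next to a carbonyl group gives a number 15 percentage points higher from compound 2 to compound 3 (beyond the scatter) in this assay, the first measured step in the series. This shows that the read-out responds to the change from tert-butoxy to ethoxy at this position, though the step is modest. Even so, compound 3 gives 1% and shows no appreciable inhibition at the single concentration tested, and the data shown offer nothing that accounts for the step.

The picture at this oxygen rests on one step, since compound 1 has no figure to add a further point. On these data alone, whether a longer chain or a benzyl group on this oxygen, or a free carboxylic acid in place of the ester, would shift the read-out further remains open.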